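The source may report more compounds than this note shows. Statements on the series, on what has been measured and on what is new or still open speak of the compounds shown alone.

Of the compounds shown here, three built on one shared core have been tested in a functional assay on MCF7 cells (Homo sapiens) for antiproliferative activity, read by MTT assay, with a stated time of 48 h; a higher number here means a weaker inhibitor, a lower number a stronger inhibitor. Compound 1 `N#CC1=C(N)Oc2c(c3nc4ccccc4nc3c3ccccc23)C12C(=O)N(Cc1cnnn1-c1ccc(Cl)cc1)c1ccccc12` reaches only the edge of what the assay can report, giving > 50000 nM, which is a limit rather than a number. Compound 2 `Cc1ccc(-n2nncc2CN2C(=O)C3(C(C#N)=C(N)Oc4c3c3nc5ccccc5nc3c3ccccc43)c3ccccc32)cc1Cl` likewise stops at a limit, with > 50000 nM. These two differ in one place, and the step from compound 1 to compound 2 is a step that the two limits leave unreadable from compound 1 to compound 2, since both ends sit at the limit of > 50000 nM in this assay, at which 2 of the 3 values shown sit. Among the measured compounds shown here, compound 3 `N#CC1=C(N)Oc2c(N)cc3nc4ccccc4nc3c2C12C(=O)N(Cc1cnnn1-c1ccccc1Cl)c1ccccc12` is the one member of the set with a real number: in this assay compound 3 gives 34400 nM, a weak effect. It stands alone among the figures shown as the only actual number, the other two being limits as described above.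

The compound still to be measured, compound 4 `N#CC1=C(N)Oc2c(N)cc3nc4ccccc4nc3c2C12C(=O)N(Cc1cnnn1-c1ccc(F)c(Cl)c1)c1ccccc12`, differs from compound 3 in a single place: 3-chloro-4-fluorophenyl in place of 2-chlorophenyl on an aromatic nitrogen. No measured step bears directly on this change; the only step shown, from compound 1 to compound 2, also exchanges groups on an aromatic nitrogen but is unreadable because both of its ends rest at the limit of > 50000 nM in this assay, at which 2 of the 3 values shown sit. No shift beyond the usual scatter is therefore expected, and the step from compound 3 to compound 4 is estimated at a 1.1-fold higher number from compound 3 to compound 4 (0.04 log units; within the scatter). Compound 4 is expected to give about 38000 nM in this assay, with a likely range from 15000 nM to 90000 nM, and a fair chance that only a limit is returned.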

Compound 4, half-maximal inhibitory concentration: 17800 nM
Beside the measured number, compound 4's estimate is 2.1-fold (0.33 log units) above it, and the stated range covers the measured number.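

In this assay, among the compounds shown here, exchanging 2-chlorophenyl for 3-chloro-4-fluorophenyl on the aromatic nitrogen of the five-membered ring gives the first readable step at this position (a 1.9-fold lower number from compound 3 to compound 4 (0.29 log units; within the scatter)), as the only earlier step there, between compound 1 and compound 2, cannot be read. The two groups differ by one added fluorine and in where the chlorine sits, yet this step does not separate them, and compound 4, like compound 3, returns a real number rather than a limit. Nothing shown gives a reason for the size of this step.

As far as these compounds go, it remains open whether a change of a different kind at this position would move the number beyond the scatter, such as an amine or a carboxylic acid on the phenyl ring, or a longer chain such as benzyl in place of the phenyl ring. Also open, from the compounds shown here alone, is how 3-chloro-4-fluorophenyl would read on the core of compound 1, a compound that returns only a limit.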